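Swapping the ester cap of compound 1 for a carbonate

A few compounds are considered here, and "the series" means these few. Any claim that something is new, unique, unknown or untested is made for them only; others in the source may bear on it.

Measured so far:
- compound 1, `C[C@@H](O)[C@H]1C(=O)N2C(C(=O)OCOC(=O)C3CCCCC3)=C(S[C@@H]3CN[C@H](C(=O)Nc4cccc(C(=O)O)c4)C3)[C@H](C)[C@H]12`: 0%
- compound 2, `C[C@@H](O)[C@H]1C(=O)N2C3=C(S[C@@H]4CN[C@@H](C4)C(=O)Nc4cccc(c4)C(=O)OCCCCOC3=O)[C@H](C)[C@H]12`: 0%

In an ADME assay on a cell-free system (plasma, Rattus norvegicus) for metabolic stability, read by LC-MS, with a stated time of 60 min, at 37 degrees C, tested at 50 uM (on this read-out higher numbers stand for a more stable compound and lower numbers for a less stable compound), compound 1 gives 0%, and compound 2 gives 0%, so compound 1 stands level with compound 2 in this assay, with no difference beyond the scatter. No single-point change between these two is described.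

Compound 3, `COC(=O)OCOC(=O)C1=C(S[C@@H]2CN[C@H](C(=O)Nc3cccc(C(=O)O)c3)C2)[C@H](C)[C@@H]2[C@@H]([C@@H](C)O)C(=O)N12`, differs from compound 1 by methoxy in place of cyclohexyl on a carbonyl carbon. For the measured compounds named here, no step of this kind between measured compounds is available. With both measured values at the floor, the step from compound 1 to compound 3 in this assay is expected to be a number 2 percentage points higher from compound 1 to compound 3 (within the scatter), none beyond the scatter. Compound 3 is expected to give 2%, within 0% to 15%.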

Compound 3, percent of the compound remaining: 0%
Beside the measured number, compound 3's estimate is 2 percentage points above it; measured number inside the range.
By their numbers in this assay, from the lowest: compounds 1, 2 and 3 (each within the scatter of the next).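

In this assay, methoxy in place of cyclohexyl on a carbonyl carbon gives no change at the digits printed from compound 1 to compound 3 (within the scatter). For the compounds shown here, this is the first step that can be read at this position, and it shows that the smaller, ring-free group does not lift the number off the bottom of the scale. With both compounds at that floor, the read-out cannot separate them, and nothing measured here explains the result. Still open, going by these compounds, is whether an amine or a longer carbon chain on this carbonyl carbon would leave any compound remaining.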